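Dopamine transporter displacement: from compound 3 to compound 4

A few compounds are considered here, and "the series" means these few. Any claim that something is new, unique, unknown or untested is made for them only; others in the source may bear on it.

Measured so far:
compound 1 `O[C@](Cc1ccccc1-c1ccccc1)(c1ccccc1)[C@@H]1CNCCO1` gives 2.9% in an assay on isolated protein for displacement of a labelled ligand from sodium-dependent dopamine transporter (Homo sapiens), tested at 1000 nM; a higher number here means more inhibition at the concentration tested (going by the name of the read-out), a lower number less inhibition
compound 2 `O[C@](Cc1ccccc1Cl)(c1ccccc1)[C@@H]1CNCCO1` gives 20.8% in this assay
compound 3 `CCOc1ccccc1C[C@@](O)(c1ccccc1)[C@@H]1CNCCO1` gives 3.8% in this assay

Compound 3 stands second highest of the three numbers. Its nearest neighbour is compound 1, the step of a number 0.9 percentage points higher from compound 1 to compound 3 (within the scatter) lying within the scatter; the furthest is compound 2, with a number 17 percentage points lower from compound 2 to compound 3 (beyond the scatter) beyond the scatter but modest. The step of a number 17.9 percentage points higher from compound 1 to compound 2 (beyond the scatter) is of similar size.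

Compound 4 `O[C@](Cc1ccccc1SC(F)(F)F)(c1ccccc1)[C@@H]1CNCCO1` differs from compound 3 by (trifluoromethyl)sulfanyl in place of ethoxy on an aromatic carbon. Going by the values given here, the steps that bear on this position, a number 17 percentage points lower from compound 2 to compound 3 (beyond the scatter) and a number 0.9 percentage points higher from compound 1 to compound 3 (within the scatter), show changes there moving the read-out by modest amounts at most, with chloro giving the highest number. Among the compounds with values here, no measured step involves (trifluoromethyl)sulfanyl, so only a modest rise, if any, is expected for compound 4 in this assay, a step of a number 8.2 percentage points higher from compound 3 to compound 4 (within the scatter). Compound 4 is estimated at 12%, with a range from 2% to 30%.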

Compound 4, a percentage reported as inhibition, at one concentration (the size of the read-out at that concentration, not a potency): 6.2%
For compound 4 the middle estimate is 5.8 percentage points above the measured one, and the stated range covers the measured number.
By their numbers in this assay, from the lowest: compounds 1, 3 and 4 (each within the scatter of the next); then compound 2.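

In this assay, the steps of a number 2.4 percentage points higher from compound 3 to compound 4 (within the scatter) and a number 3.3 percentage points higher from compound 1 to compound 4 (within the scatter) place (trifluoromethyl)sulfanyl with ethoxy and phenyl, so three different groups on this aromatic carbon cannot be told apart. Chloro alone stands apart from this group, as shown by a number 14.6 percentage points lower from compound 2 to compound 4 (beyond the scatter), although that step remains modest. No measurement available here explains this separation. From the compounds shown here alone, whether fluoro, bromo or an amine on this aromatic carbon would match compound 2 stays open, as does whether any group at this position would give a much higher number in this assay.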